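The source may report more compounds than this note shows. Statements on the series, on what has been measured and on what is new or still open speak of the compounds shown alone.

Measured in a functional assay on VCaP cells (Homo sapiens) for antiproliferative activity, read by propidium iodide staining, with a stated time of 96 h; a lower number here means a stronger inhibitor, a higher number a weaker inhibitor:
Compound 1 `CC(O)(CSc1ccc(S(F)(F)(F)(F)F)cc1)C(=O)Nc1ccc([N+](=O)[O-])c(C(F)(F)F)c1`: 10100 nM
Compound 2 `CC(O)(CSc1ccc(S(F)(F)(F)(F)F)cc1)C(=O)Nc1ccc(C#N)cc1C(F)(F)F`: 20500 nM

Of these two numbers, compound 2 holds the higher at 20500 nM, which makes it the weaker inhibitor of the pair, and the gap to compound 1 lies beyond the usual scatter. The next compound, compound 3 `CC(O)(CSc1ccc(S(F)(F)(F)(F)F)cc1)C(=O)Nc1ccc([N+](=O)[O-])cc1C(F)(F)F`, keeps the rest of compound 2 and carries nitro in place of cyano on an aromatic carbon, meta to a trifluoromethyl group and para to a large group (nitro in place of cyano on an aromatic carbon). Within the data shown here, no measured pair isolates this change. Compound 1 also carries nitro and gives 10100 nM, so a small move toward a lower number is expected in this assay, probably within the scatter. The estimated change is a 1.6-fold lower number from compound 2 to compound 3 (0.20 log units; within the scatter). For compound 3 the expected value is 13000 nM, within an estimated range of 6000 nM to 28000 nM.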

Compound 3, half-maximal inhibitory concentration: 26300 nM
Beside the measured number, compound 3's estimate is 2.0-fold (0.31 log units) below it, and the stated range covers the measured number.
By their numbers in this assay, from the lowest: compound 1; then compounds 2 and 3 (each within the scatter of the next).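

Among these compounds, on an aromatic carbon meta to a trifluoromethyl group and para to a large group, nitro in place of cyano gives a 1.3-fold higher number from compound 2 to compound 3 (0.11 log units; within the scatter) in this assay, the first step in this set that isolates a single change. At this position, then, the two groups cannot be told apart in this assay, a point that compound 1, which differs from compound 2 in more than one place, could not settle. Nothing available here accounts for this result.

The compounds shown leave open whether a different group at this position, such as an amine or a carboxylic acid, would give a step beyond the scatter. They also leave open whether nitro and cyano would match in the same way on a core with another thioether substituent.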